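The source may hold more compounds than are shown below. What is called first, only, known or untested is meant among the compounds shown, and "the series" means these compounds.

Three members of the series have been run in a functional assay on Ca-Ski cells (Homo sapiens) for cytotoxicity, read by sulforhodamine B assay, with a stated time of 48 h; a higher number here means a weaker inhibitor, a lower number a stronger inhibitor. Compound 3 `O=c1cc(-c2ccccc2)oc2cc(OCCCCNc3nc4ccc(I)cc4s3)cc(O)c12` gives 13.2 ug/mL. Compound 1 `O=c1cc(-c2ccccc2)oc2cc(OCCCCNc3nc4ccccc4s3)cc(O)c12` gives 14.6 ug/mL, and compound 2 `Cc1ccc2nc(NCCCCOc3cc(O)c4c(=O)cc(-c5ccccc5)oc4c3)sc2c1` gives 15.5 ug/mL. Among the measured compounds shown here, compound 3 returns the lowest of the three numbers, but the steps leading to it, a 1.1-fold lower number from compound 1 to compound 3 (0.04 log units; within the scatter) and a 1.2-fold lower number from compound 2 to compound 3 (0.07 log units; within the scatter), lie within the scatter, as does a 1.1-fold higher number from compound 1 to compound 2 (0.03 log units; within the scatter); on these numbers no compound can be set apart from the others.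

Compound 4 `O=C(O)c1ccc2nc(NCCCCOc3cc(O)c4c(=O)cc(-c5ccccc5)oc4c3)sc2c1` is the next case: carboxy in place of iodo on an aromatic carbon. The three measured steps all exchange the substituent at this same aromatic carbon, and hydrogen, methyl and iodo each left the number essentially where it was. Carboxy is a different kind of group, bringing a hydrogen-bond donor and a hydrogen-bond acceptor, and no measured step in the series carries such a group, so the expectation rests only on the insensitivity seen so far and must be given a wider range than the measured spread. The expected step is a 1.2-fold higher number from compound 3 to compound 4 (0.08 log units; within the scatter), that is, none beyond the scatter. Compound 4 is therefore estimated at 16 ug/mL in this assay, with a range from 7 ug/mL to 40 ug/mL.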

Compound 4, half-maximal inhibitory concentration: 12.1 ug/mL
The estimate for compound 4 lay 1.3-fold (0.12 log units) above the measured number; the range from low to high includes it.
By their numbers in this assay, from the lowest: compounds 4, 3, 1 and 2 (each within the scatter of the next).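

In this assay, carboxy at this aromatic carbon stays within the scatter of every substituent tested there, with a 1.1-fold lower number from compound 3 to compound 4 (0.04 log units; within the scatter) as the step from iodo, a 1.3-fold lower number from compound 2 to compound 4 (0.11 log units; within the scatter) as the step from methyl and a 1.2-fold lower number from compound 1 to compound 4 (0.08 log units; within the scatter) as the step from hydrogen. The earlier compounds shown here covered only hydrogen, methyl and iodo, none with a hydrogen-bond donor or acceptor, whereas 6-carboxy-1,3-benzothiazol-2-yl brings one of each and three heavy atoms, and compound 4 still cannot be told apart from compounds 1, 2 and 3. No supporting data accompany these numbers that would explain why this position gives so little separation.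

Whether this insensitivity extends beyond the four compounds shown remains open, for example to a methyl ester, a primary amide or an aminomethyl group on the same aromatic carbon. The compounds shown also all keep the same butyl-length link between the shared core and the ring bearing the substituent, so a shorter or longer chain there, or a hydroxy or methoxy group on the shared core, is a separate question.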